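This account rests on a few compounds, and the source may have more. Where it says the series, first, only, none or still open, it means among the compounds named here.

The compounds measured so far:

Compound 1, `Cc1ccc(-c2oc3ccc(C(=O)O)cc3c(=O)c2O)cc1`: 6%
Compound 2, `O=C(O)c1ccc2oc(-c3ccccc3Br)c(O)c(=O)c2c1`: 22%
Compound 3, `O=C(O)c1ccc(-c2oc3ccc(C(=O)O)cc3c(=O)c2O)cc1`: 23%

All three were tested in a functional assay on the whole organism (stomach) for inhibition, with Rattus norvegicus as the target, at a dose of 80 mg/kg; on this read-out higher numbers stand for more inhibition at the one dose given (going by the name of the read-out) and lower numbers for less inhibition. Compound 1 gives the lowest of the three numbers. The two measured steps, a number 16 percentage points higher from compound 1 to compound 2 (beyond the scatter) and a number 17 percentage points higher from compound 1 to compound 3 (beyond the scatter), both change the ring attached to the shared core, and both raise inhibition by a modest amount.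

Compound 4, `Cc1ccc(-c2oc3ccc(C(=O)O)cc3c(=O)c2OC(C)C)cc1`, differs from compound 1 elsewhere: isopropyl in place of hydrogen on an oxygen on an aromatic ring Cut one bond further out, the change reads hydroxy to isopropoxy. Neither measured step touches this oxygen, so no direct guide exists for this change, and the measured steps bear on it only in showing that small changes to compound 1 have so far moved the number modestly. Compound 4 is therefore expected to stay close to compound 1, with no step beyond the usual scatter. Compound 4 is estimated at 10%, with a range from 0% to 28%. The expected step is a number 4 percentage points higher from compound 1 to compound 4 (within the scatter), within the scatter.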

Compound 4, a percentage reported as inhibition, in the whole organism at one dose (the size of the read-out at that dose, not a potency): 8%
Compound 4: middle estimate off by 2 percentage points, on the high side, and the stated range covers the measured number.
By their numbers in this assay, from the lowest: compounds 1 and 4 (each within the scatter of the next); then compounds 2 and 3 (each within the scatter of the next).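

In this assay, going by these compounds alone, hydroxy to isopropoxy gives a number 2 percentage points higher from compound 1 to compound 4 (within the scatter), so at this oxygen, which the earlier steps left untouched, isopropyl in place of hydrogen brings no difference that can be told from the scatter. This says little about whether the hydrogen matters in general, since compound 1 already gives the lowest number of the first three compounds and any loss would have had little room to show. Nothing available explains this result.

As far as these compounds go, it remains open whether the same change would also leave the number unmoved on compound 2 or compound 3, which both stand above compound 1. Also open, from the compounds shown here alone, is how a different group on this oxygen would read, such as a methyl, a longer chain or a chain ending in a carboxylic acid.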